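The source may hold more compounds than are shown below. What is called first, only, known or untested is meant among the compounds shown, and "the series" means these compounds.

Measured so far:
compound 1, `Cc1nc(C(N)=O)c(N)c2c1C(=O)N(Cc1ccccc1)C2=O`: < 5000 nM
compound 2, `Cc1noc(-c2nc(C)c3c(c2N)C(=O)N(Cc2ccc(Cl)cc2)C3=O)n1`: < 5000 nM

In a physicochemical assay for solubility, using the shake flask method, in simulated intestinal fluid, measured as kinetic solubility, with a stated time of 2 h, at 25 degrees C, at pH 6.5 (on this read-out lower numbers stand for lower solubility and higher numbers for higher solubility), compound 1 gives < 5000 nM, which is a limit of the assay and not a number. In this assay compound 2 gives < 5000 nM, again a limit rather than a number. Among the compounds with values here, compound 2 thus stands where the only other value shown stands: the limit of < 5000 nM in this assay, at which 2 of the 2 values shown sit. No measured step can be read between the two, as both sit at the limit.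

Compound 3, `Cc1noc(-c2nc(C)c3c(c2N)C(=O)N(Cc2ccc(OC(F)F)cc2)C3=O)n1`, is not yet measured. It differs from compound 2 in one place: difluoromethoxy in place of chloro on an aromatic carbon. Chloro leaves and difluoromethoxy enters on the same aromatic carbon. With both measured values at the limit, the step in this assay is expected to be a step that the limit leaves unreadable from compound 2 to compound 3, not beyond the usual scatter. Compound 3 is accordingly estimated at 3000 nM, with a range from 600 nM to 15000 nM, a further limit reading being the likelier outcome.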

Compound 3, solubility: < 5000 nM
Compound 3 was reported as a limit; the forecaster's own chance of this, stated with the estimate: 65%; the middle value is on the limit's open side.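

In this assay compound 3 gives < 5000 nM, a limit and not a number. No step can be read between compound 2 and compound 3, both sitting at the limit: the limit of < 5000 nM in this assay, at which 3 of the 3 values shown sit.

The compounds shown leave open where any of them lies beneath that limit, and so what difluoromethoxy in place of chloro does to the read-out.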